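The source may hold more compounds than are shown below. What is called first, only, known or untested is meant among the compounds shown, and "the series" means these compounds.

Measured in an ADME assay on microsomes from liver (Homo sapiens) for metabolic stability; on this read-out higher numbers stand for a longer-lived compound and lower numbers for a shorter-lived compound:

- compound 1 `CC(C)C(Cc1ncc[nH]1)c1ccc(-c2ccc3cccc(F)c3c2)[nH]c1=O`: 0.106 h
- compound 2 `CC(C)C(c1ncco1)c1ccc(-c2ccc3cccc(F)c3c2)[nH]c1=O`: 0.178 h
- compound 3 `CC(C)C(/C=C1/CCNC1=O)c1ccc(-c2ccc3cccc(F)c3c2)[nH]c1=O`: 0.987 h

Compound 3 has the highest number of the three, at 0.987 h. The next step leads to compound 4 `Cc1c[nH]c(C(c2ccc(-c3ccc4cccc(F)c4c3)[nH]c2=O)C(C)C)n1`: a group of 6 heavy atoms (4 carbon, 2 nitrogen; one five-membered aromatic ring with 2 hetero atoms) in place of a group of 7 heavy atoms (5 carbon, 1 nitrogen, 1 oxygen; one five-membered non-aromatic ring with 1 hetero atom), on a saturated chain carbon bound to an aromatic carbon and a saturated chain carbon. Here 4-methyl-1H-imidazol-2-yl enters on a saturated chain carbon bound to an aromatic carbon and a saturated chain carbon, so a five-membered aromatic ring returns at the place where compounds 1 and 2 carry theirs.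

Among the compounds with values here, two measured steps bear on this change when read in reverse: a 9.3-fold higher number from compound 1 to compound 3 (0.97 log units; beyond the scatter) and a 5.5-fold higher number from compound 2 to compound 3 (0.74 log units; beyond the scatter). Both lie beyond the scatter, and in each the non-aromatic ring group replaces a group holding a five-membered aromatic ring. The third step, a 1.7-fold higher number from compound 1 to compound 2 (0.23 log units; within the scatter), lies within the scatter, so compounds 1 and 2 give one low level rather than two. Within the data shown here, none of the measured compounds carries the methyl group of compound 4, and the estimate has to be read with that gap in mind. A drop of similar size to those two steps is expected, beyond the scatter: a 6.6-fold lower number from compound 3 to compound 4 (0.82 log units; beyond the scatter). Compound 4 is estimated at 0.15 h, with an expected range of 0.07 h to 0.35 h.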

Compound 4, half-life: 0.09 h
Compound 4: the middle estimate sits 1.7-fold (0.22 log units) above what was measured; the measured number falls inside the stated range.
By their numbers in this assay, from the lowest: compounds 4, 1 and 2 (each within the scatter of the next); then compound 3.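

The step of an 11-fold lower number from compound 3 to compound 4 (1.04 log units; beyond the scatter) in this assay shows that a five-membered aromatic ring bound directly at this saturated chain carbon, now with a methyl group, does not reach the level of the non-aromatic ring group of compound 3. Both a 2.0-fold lower number from compound 2 to compound 4 (0.30 log units; within the scatter) and a 1.2-fold lower number from compound 1 to compound 4 (0.07 log units; within the scatter) lie within the scatter, so 4-methyl-1H-imidazol-2-yl, 1,3-oxazol-2-yl and (1H-imidazol-2-yl)methyl form one low level, and among these four compounds only compound 3 stands apart from it, with no aromatic ring group going against that split. Nothing available explains why the non-aromatic ring group stands apart from the three aromatic ring groups.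

The compounds shown leave open whether the higher number of compound 3 goes with the five-membered non-aromatic ring itself or with its double bonds outside aromatic rings, which a fully saturated version of that ring would separate. Going by these compounds, it also stays open whether an open-chain amide, an amine or a carboxylic acid at this place would fall with compound 3 or at the low level.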